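The compounds below may be only part of what the source reports. "The series", "measured", "known", "first", "only" and "open" are said of these compounds alone.

Of the compounds shown here, two have so far been tested in a functional assay on HCT-116 cells (Homo sapiens) for cytotoxicity; a higher number here means a weaker inhibitor, a lower number a stronger inhibitor. Compound 1 (`COc1cc(/C=C\c2ccc3ccccc3n2)cc(OC)c1OC`) gives 316 nM in this measurement, a real number to hold on to. Compound 2 (`COc1cc(/C=C\c2ccc3nc(C)c(C)nc3c2)cc(OC)c1OC`) gives no number, and its entry of > 15800 nM is a limit of the assay. Compound 2 therefore stands at the limit of > 15800 nM in this assay, at which 1 of the 2 values shown sits, and has no exact position on the scale.

Compound 3 (`COc1cc(/C=C/c2ccc3nc(C)c(C)nc3c2)cc(OC)c1OC`) is the partner of compound 2, and the change between them is simple: the two compounds have the same atoms and bonds and differ only in configuration as drawn: 1 of 1 stereo elements differ; a double bond is drawn Z in compound 2 and E in compound 3 in all. A double bond is drawn Z in compound 2 and E in compound 3, and nothing else differs. Within the data shown here, no measured pair shows what such a change does in this assay, so the expectation rests on compound 2 alone. Among the measured compounds shown here, with the limit of > 15800 nM as the only anchor for compound 2, no step beyond the usual scatter is expected, and a second result at the limit is the likeliest outcome. The expected change is a step that the limit leaves unreadable from compound 2 to compound 3 and remains a rough estimate. For compound 3 the estimated value is 20000 nM with an expected range of 8000 nM to 50000 nM in this assay.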

Compound 3, half-maximal inhibitory concentration: > 15800 nM
Compound 3 ended at the assay's limit; the forecaster's own chance of this, stated with the estimate: 75%; the middle value lies beyond the limit too.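

Compound 2 and compound 3 both end at a limit rather than a number, so no step between them can be read: the limit of > 15800 nM in this assay, at which 2 of the 3 values shown sit.

The compounds shown leave open how far past that limit either compound lies in this assay, and whether the Z or E drawing of the double bond makes any difference there.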